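The compounds below may be only part of what the source reports. "The series", "measured", "known", "first", "only" and "open" are said of these compounds alone.

Working notes on the series. Compound 1 `Cc1cc(-c2ccccc2)n(/C(N)=N/S(=O)(=O)c2cc(C)c(Cl)cc2SCc2cccc3ccccc23)n1` gives 12000 nM in an ADME assay on HaCaT cells (Homo sapiens) for cytotoxicity, read by MTT assay, with a stated time of 72 h; a higher number here means a weaker inhibitor, a lower number a stronger inhibitor. Compound 2 `Cc1cc(-c2ccccc2)n(/C(N)=N/S(=O)(=O)c2cc(C)c(Cl)cc2SCc2cccc(Cl)c2)n1` gives 18000 nM in this assay; the step of a 1.5-fold higher number from compound 1 to compound 2 (0.18 log units; within the scatter). Compound 3 `Cc1cc(S(=O)(=O)/N=C(\N)n2nccc2-c2ccccc2)c(SCc2cccc(C(F)(F)F)c2)cc1Cl` gives 18000 nM in this assay, level with compound 2 at the digits reported and together with it the highest of the three numbers; its nearest neighbour is compound 2, with no change at the digits reported, and its furthest is compound 1, a gap that stays within the scatter.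

Compound 4 `Cc1cc(-c2ccccc2)n(/C(N)=N/S(=O)(=O)c2cc(C)c(Cl)cc2SCc2cccc(C(F)(F)F)c2)n1` differs from compound 3 by methyl in place of hydrogen on an aromatic carbon, placed on an aromatic carbon of a five-membered aromatic ring with 2 nitrogen, two ring bonds from the ring atom that bears a phenyl group. Within the data shown here, no measured step touches this position: the only measured step, from compound 1 to compound 2, concerns the group on the saturated chain carbon bound to a sulfur and was itself within the scatter, and all three numbers so far sit within the scatter of one another. The expected step from compound 3 to compound 4 in this assay is therefore no change at the digits printed from compound 3 to compound 4 (within the scatter), nothing beyond the scatter. Compound 4 is estimated at 18000 nM, with a range from 8000 nM to 40000 nM.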

Compound 4, half-maximal inhibitory concentration: 40000 nM
The estimate for compound 4 lay 2.2-fold (0.35 log units) below the measured number; the measured number falls inside the stated range.
By their numbers in this assay, from the lowest: compounds 1, 2 and 3 (each within the scatter of the next); then compound 4.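

In this assay, among these compounds, methyl in place of hydrogen on the aromatic carbon two ring bonds from the ring atom that bears a phenyl group gives a 2.2-fold higher number from compound 3 to compound 4 (0.35 log units; beyond the scatter), so this position, untouched by the earlier compounds, produces the first single-place change to clear the scatter, though only modestly. With that methyl present, the group on the saturated chain carbon bound to a sulfur also separates compounds: trifluoromethyl in place of chloro gives a 2.2-fold higher number from compound 2 to compound 4 (0.35 log units; beyond the scatter), and 3-(trifluoromethyl)phenyl in place of naphthalen-1-yl gives a 3.3-fold higher number from compound 1 to compound 4 (0.52 log units; beyond the scatter), whereas the earlier step between 3-chlorophenyl and naphthalen-1-yl stayed within the scatter. No measurement at hand accounts for any of these steps.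

As far as these compounds go, the methyl step rests on a single pair carrying 3-(trifluoromethyl)phenyl, so it remains open whether the same step appears with 3-chlorophenyl or naphthalen-1-yl on that chain carbon. Also open, from the compounds shown here alone, is how an ethyl group, a hydroxymethyl group or a carboxylic acid on the same aromatic carbon would read in this assay, and whether any of them would move the number further than methyl does.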